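Methoxy to hydroxy on the aromatic ring

The source may report more compounds than this note shows. Statements on the series, on what has been measured and on what is new or still open speak of the compounds shown alone.

Measured compounds:
compound 1 `S=C(NCc1ccccc1)c1ccccc1` — 162000 nM
compound 2 `COc1ccc(C(=S)NCc2ccccc2)cc1` — 129000 nM

In a functional assay on thoracic aorta (Rattus norvegicus, strain Wistar) (on this read-out higher numbers stand for weaker inhibition and lower numbers for stronger inhibition), compound 2 gives 129000 nM and compound 1 gives 162000 nM; the step of a 1.3-fold lower number from compound 1 to compound 2 (0.10 log units; within the scatter) lies within the scatter, so the two are not separated. Compound 3 `Oc1ccc(C(=S)NCc2ccccc2)cc1` differs from compound 2 by hydrogen in place of methyl on an oxygen on an aromatic ring. Going by the values given here, the only measured step, a 1.3-fold lower number from compound 1 to compound 2 (0.10 log units; within the scatter), concerns the methoxy group that is now cut back to hydroxy and was itself within the scatter, so for compound 3 no step beyond the scatter is expected: a 1.0-fold higher number from compound 2 to compound 3 (0.00 log units; within the scatter). Compound 3 is estimated at 130000 nM, with a range from 50000 nM to 350000 nM.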

Compound 3, half-maximal inhibitory concentration: 347000 nM
Compound 3: the middle estimate sits 2.7-fold (0.43 log units) below what was measured; the measured number falls inside the stated range.
By their numbers in this assay, from the lowest: compounds 2 and 1 (each within the scatter of the next); then compound 3.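

In this assay, going by these compounds alone, the substituent on the aromatic ring now separates compounds: cutting methoxy back to hydroxy gives a 2.7-fold higher number from compound 2 to compound 3 (0.43 log units; beyond the scatter), whereas the only earlier step stayed within the scatter. Hydroxy also separates from hydrogen, with a 2.1-fold higher number from compound 1 to compound 3 (0.33 log units; beyond the scatter), so this place is not indifferent to every change, and hydroxy is the one group of the three that stands apart. No available evidence bears on this difference. From the compounds shown here alone, it remains open whether a longer chain on the oxygen, such as ethoxy, or an amine in place of the hydroxy would group with methoxy or with hydroxy.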